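The compounds below may be only part of what the source reports. "The series", "measured", "known", "first", "only" and "open" are said of these compounds alone.

Among the measured compounds shown here, in a toxicity assay on HUVEC cells (Homo sapiens) for cytotoxicity, read by MTT assay, with a stated time of 96 h (on this read-out lower numbers stand for stronger inhibition and higher numbers for weaker inhibition), compound 3 `O=C1NC(=O)/C(=C\c2ccc(OCC(=O)N3N=C(c4ccc(F)cc4)CC3c3ccco3)cc2)S1` gives 700 nM, the only actual number so far. Compound 1 `O=C1NC(=O)/C(=C\c2ccc(OCC(=O)N3N=C(c4ccccc4)CC3c3ccc(C(F)(F)F)cc3)cc2)S1` reads > 10000 nM, which is a limit. Compound 2 `O=C1NC(=O)/C(=C\c2ccc(OCC(=O)N3N=C(c4ccc(F)cc4)CC3c3ccccc3)cc2)S1` reads > 10000 nM, also a limit. Next is compound 4 `O=C1NC(=O)/C(=C\c2ccc(OCC(=O)N3N=C(c4ccc(F)cc4)CC3c3ccc(C(F)(F)F)cc3)cc2)S1`, with 4-(trifluoromethyl)phenyl in place of furan-2-yl on a saturated ring carbon. The closest measured step is an at least 14-fold lower number from compound 2 to compound 3 (1.15 log units; beyond the scatter), large and seen with furan-2-yl entering in place of phenyl at that same carbon. Compound 1 also carries 4-(trifluoromethyl)phenyl there. Losing furan-2-yl is therefore expected to give a large step in this assay towards higher numbers, probably reaching the limit. The expected change is a 14-fold higher number from compound 3 to compound 4 (1.15 log units; beyond the scatter). For compound 4 the estimate is 10000 nM, with an expected range of 3000 nM to 30000 nM.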

Compound 4, half-maximal inhibitory concentration: 6000 nM
Beside the measured number, compound 4's estimate is 1.7-fold (0.22 log units) above it, and the stated range covers the measured number.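

In this assay there is an 8.6-fold higher number from compound 3 to compound 4 (0.93 log units; beyond the scatter) as 4-(trifluoromethyl)phenyl enters on the saturated ring carbon, so a group with a six-membered aromatic ring now has a measured number there rather than a limit. Trifluoromethyl in place of hydrogen gives an at least 1.6-fold lower number from compound 2 to compound 4 (0.22 log units; that floor lies within the scatter) and fluoro in place of hydrogen gives an at least 1.6-fold lower number from compound 1 to compound 4 (0.22 log units; that floor lies within the scatter) so neither single change is shown to exceed the scatter. Both steps start from a limit: the limit of > 10000 nM in this assay, at which 2 of the 4 values shown sit.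

From the compounds shown here alone, how a thiophene ring or an amine would read on that carbon remains open. Furan-2-yl is the only five-membered ring there, so ring size and the ring oxygen cannot be separated.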